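Piperazine for Piperidine on a Shared Core

This account rests on a few compounds, and the source may have more. Where it says the series, first, only, none or still open, it means among the compounds named here.

Measured in a functional assay on HCT-116 cells (Homo sapiens) for antiproliferative activity, read by CCK-8 assay, with a stated time of 72 h, tested at 8 uM; a higher number here means a stronger effect of the compound at the concentration tested, a lower number a weaker effect:
compound 1 `Cc1ccc(Nc2nc(Cl)nc3c2ncn3Cc2ccc(C(=O)Nc3ccccc3N)cc2)cc1` gives 81.5%;
compound 2 `CC1CCN(c2nc(Cl)nc3c2ncn3Cc2ccc(C(=O)Nc3ccccc3N)cc2)CC1` gives 78.6%.

Going by the values given here, compound 2 stands lowest of the two numbers, with compound 1 its nearest neighbour; the single measured step, a number 2.9 percentage points lower from compound 1 to compound 2 (within the scatter), lies within the scatter. Compound 3 `CN1CCN(c2nc(Cl)nc3c2ncn3Cc2ccc(C(=O)Nc3ccccc3N)cc2)CC1` has not yet been measured and differs from compound 2 by 4-methylpiperazin-1-yl in place of 4-methylpiperidin-1-yl on an aromatic carbon. Among the compounds with values here, the only step that bears on this, a number 2.9 percentage points lower from compound 1 to compound 2 (within the scatter), also swapped the group at this place and stayed within the scatter, so in this assay no step beyond the scatter is expected. Compound 3 is therefore estimated at 75%, ranging from 58% to 90%. The expected step is a number 3.6 percentage points lower from compound 2 to compound 3 (within the scatter), within the scatter.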

Compound 3, a percentage reported as inhibition, at one concentration (the size of the read-out at that concentration, not a potency): 72.8%
Compound 3: the middle estimate sits 2.2 percentage points above what was measured; the measured number falls inside the stated range.
By their numbers in this assay, from the lowest: compounds 3, 2 and 1 (each within the scatter of the next).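

In this assay, exchanging 4-methylpiperidin-1-yl for 4-methylpiperazin-1-yl on the shared core gives a number 5.8 percentage points lower from compound 2 to compound 3 (within the scatter), and the exchange of (4-methylphenyl)amino for the same group gives a number 8.7 percentage points lower from compound 1 to compound 3 (within the scatter). This position therefore now carries three different groups, including a ring with 2 hetero atoms, with no step beyond the scatter. No measurement available here explains these results.

As far as these compounds go, it remains open whether a morpholin-4-yl group or a carboxylic acid at this carbon would also stay within the scatter. A single-concentration read-out also leaves any difference in potency among these compounds unresolved.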